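The source may report more compounds than this note shows. Statements on the series, on what has been measured and on what is new or still open speak of the compounds shown alone.

In a functional assay on HeLa cells (Homo sapiens) for antiproliferative activity, read by sulforhodamine B assay (on this read-out higher numbers stand for weaker inhibition of growth and lower numbers for stronger inhibition of growth), compound 1 `CCCC[C@@H]1O[C@H](COCc2ccccc2)[C@@H](OCc2ccccc2)[C@H](OCc2ccccc2)[C@H]1O` gives > 50000 nM, a limit of the assay and not a number. Compound 2 `CC(C)C[C@@H]1O[C@H](COCc2ccccc2)[C@@H](OCc2ccccc2)[C@H](OCc2ccccc2)[C@H]1O` gives > 50000 nM, also a limit. Going by the values given here, compound 3 `C=CC[C@@H]1O[C@H](COCc2ccccc2)[C@@H](OCc2ccccc2)[C@H](OCc2ccccc2)[C@H]1O` gives 26200 nM, the only actual number among the three. Compound 4 `O[C@@H]1[C@@H](OCc2ccccc2)[C@H](OCc2ccccc2)[C@@H](COCc2ccccc2)O[C@H]1CC1CC1` differs from it as follows: cyclopropyl in place of vinyl on a saturated chain carbon bound to a saturated ring carbon. In words, this is cyclopropyl in place of vinyl on a saturated chain carbon bound to a saturated ring carbon. Two measured steps change the same place, an at least 1.9-fold lower number from compound 1 to compound 3 (0.28 log units; that floor lies within the scatter) and an at least 1.9-fold lower number from compound 2 to compound 3 (0.28 log units; that floor lies within the scatter), and each floor lies within the scatter. In this assay only a small drift toward a higher number is therefore expected, with no step beyond the scatter. The estimated step is a 1.5-fold higher number from compound 3 to compound 4 (0.18 log units; within the scatter). Compound 4 is estimated at 40000 nM, with an expected range of 20000 nM to 80000 nM.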

Compound 4, concentration for 50% growth inhibition: > 50000 nM
Compound 4: a limit, no number; the forecaster's own chance of this, stated with the estimate: 50%; middle value at least 1.2-fold (0.09 log units) away from the limit.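

In this assay, cyclopropyl in place of vinyl on a saturated chain carbon bound to a saturated ring carbon gives an at least 1.9-fold higher number from compound 3 to compound 4 (0.28 log units; that floor lies within the scatter), so this change cannot be told apart from the scatter. Going by these compounds alone, compound 4 gives > 50000 nM, a limit and not a number, which leaves vinyl as the only group of the four at this place with an actual number. The steps from compound 1 and from compound 2 to compound 4 cannot be read.

From the compounds shown here alone, how compound 1, compound 2 and compound 4 compare stays hidden: the limit of > 50000 nM in this assay, at which 3 of the 4 values shown sit. Whether an amine or a longer chain at this place would give a number also stays open.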